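A Change on the Carbonyl Arm: From Compound 1 to Compound 4

A few compounds are considered here, and "the series" means these few. Any claim that something is new, unique, unknown or untested is made for them only; others in the source may bear on it.

Of the compounds shown here, three built on a shared core have been tested in an ADME assay on MT4 cells (Homo sapiens) for cytotoxicity, read by MTT assay; on this read-out lower numbers stand for higher toxicity in this test and higher numbers for lower toxicity in this test. Compound 1, `O=C1c2ccccc2C(=O)N1CCOC(=S)N(C(=O)c1ccc(C(F)(F)F)cc1)c1ccc(Cl)cc1`, gives 10000 nM in this assay, the lowest of the three numbers. Compound 3, `O=C1c2ccccc2C(=O)N1CCOC(=S)N(C(=O)c1ccc(Cl)c(Cl)c1)c1ccccc1`, gives 52000 nM, a gap from compound 1 that lies beyond the usual scatter, while compound 2, `Cc1ccc(N(C(=O)c2cccc([N+](=O)[O-])c2)C(=S)OCCN2C(=O)c3ccccc3C2=O)cc1`, gives 100000 nM, the furthest from compound 1 and likewise beyond the scatter. Compound 1 is thus the most toxic of the three on this read-out.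

The step to compound 4, `O=C1c2ccccc2C(=O)N1CCOC(=S)N(C(=O)c1ccc(Cl)cc1Cl)c1ccc(Cl)cc1`, changes only the group on the carbonyl carbon whose other neighbour is the amide-type nitrogen: 2,4-dichlorophenyl in place of 4-(trifluoromethyl)phenyl on a carbonyl carbon. For the measured compounds named here, no pair of measured compounds differing in this one place is available, so the size of the step cannot be read from the data. Because compound 1 sits at 10000 nM and its nearest neighbour compound 3 at 52000 nM, a modest rise toward lower toxicity is expected, a step of a 2.0-fold higher number from compound 1 to compound 4 (0.30 log units; within the scatter). Compound 4 is therefore estimated at 20000 nM, with a range from 6000 nM to 60000 nM.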

Compound 4, half-maximal cytotoxic concentration: 18000 nM
The estimate for compound 4 lay 1.1-fold (0.05 log units) above the measured number, within the range that was stated.
By their numbers in this assay, from the lowest: compounds 1 and 4 (each within the scatter of the next); then compounds 3 and 2 (each within the scatter of the next).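

In this assay, for the compounds shown here, placing 2,4-dichlorophenyl in place of 4-(trifluoromethyl)phenyl on a carbonyl carbon gives a 1.8-fold higher number from compound 1 to compound 4 (0.26 log units; within the scatter), the first step that can be read at this position. With the rest of the molecule unchanged, this test therefore does not separate these two groups, even though they differ in their halogen atoms and in heavy-atom count. No measurement shown here offers an explanation for this result.

As far as these compounds go, it remains open how this assay would respond to a group of a different kind on this carbonyl carbon, such as an aminophenyl group, a carboxyphenyl group or a longer alkyl chain. Compound 2 and compound 3 differ from compound 1 in more than one place, so their values do not show how much this position contributes.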